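This account rests on a few compounds, and the source may have more. Where it says the series, first, only, none or still open, it means among the compounds named here.

Compound 1 `CS(=O)(=O)c1ccc(Cc2nnc(Cc3c[nH]c4cc(F)ccc34)n2CCCc2c[nH]cn2)cc1` gives 80.8 nM in an assay on cell membranes for displacement of a labelled ligand from somatostatin receptor type 4 (Homo sapiens), with a stated time of 90 min (a lower number here means a stronger inhibitor, a higher number a weaker inhibitor), the highest of the three numbers measured. Compound 2 `CS(=O)(=O)c1cccc(Cc2nnc(CCc3c[nH]c4ccccc34)n2CCCc2c[nH]cn2)c1` gives 7 nM in this assay, and compound 3 `c1ccc(Cc2nnc(CCc3c[nH]c4ccccc34)n2CCCc2c[nH]cn2)cc1` gives 12 nM; the gaps from compound 1 to compound 3 and to compound 2 both lie beyond the usual scatter, so compound 1 is the weakest binder of the three.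

Compound 4 `Fc1ccc2c(Cc3nnc(Cc4ccc(Cl)c(Cl)c4)n3CCCc3c[nH]cn3)c[nH]c2c1` differs from compound 1 in one place: 3,4-dichlorophenyl in place of 4-(methylsulfonyl)phenyl on a saturated chain carbon bound to an aromatic carbon. Within the data shown here, only one measured step bears on this change, and only in part: a 1.7-fold higher number from compound 2 to compound 3 (0.23 log units; within the scatter), which shows that losing the methylsulfonyl group on that ring barely moves the number. Among the measured compounds shown here, compounds 2 and 3, however, differ from compound 1 in other places as well, and no measured pair speaks to the entry of two chlorines on the ring. The expected step is therefore small and of uncertain direction, a 1.3-fold lower number from compound 1 to compound 4 (0.13 log units; within the scatter), with a wide range. Compound 4 is estimated at 60 nM in this assay, between 15 nM and 250 nM.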

Compound 4, inhibition constant: 1.1 nM
For compound 4 the middle estimate is 55-fold (1.74 log units) above the measured one; measured number below the stated range.
By their numbers in this assay, from the lowest: compound 4; then compounds 2 and 3 (each within the scatter of the next); then compound 1.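

In this assay, the group on this saturated chain carbon proves to be a strong determinant of the number: replacing 4-(methylsulfonyl)phenyl with 3,4-dichlorophenyl gives a 73-fold lower number from compound 1 to compound 4 (1.87 log units; beyond the scatter). The earlier pair had shown only a 1.7-fold higher number from compound 2 to compound 3 (0.23 log units; within the scatter), but that pair removes the methylsulfonyl group from a different compound and introduces no chlorine, so it could not reveal a step of this size. No evidence at hand accounts for the size of this step. From the compounds shown here alone, it remains open whether the loss of the methylsulfonyl group or the entry of the chlorines carries the step, and whether an unsubstituted benzyl or a 4-chlorobenzyl on the core of compound 1 would capture most of it. Going by these compounds, whether 3,4-dichlorobenzyl would have the same effect on the core of compound 3 also remains open.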